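The source may hold more compounds than are shown below. What is called first, only, known or untested is meant among the compounds shown, and "the series" means these compounds.

Measured compounds:
compound 1, `CCn1c(SCC(=O)c2ccccc2)nnc1-c1ccc(OC)cc1`, 61%
compound 2, `CCn1c(SCC(=O)c2ccccc2)nnc1-c1ccccc1`, 51%
compound 3, `CCn1c(SC/C(=N/O)c2ccccc2)nnc1-c1ccc(OC)c(OC)c1`, 71%

All three were tested in a functional assay on the whole organism (strain albino) for inhibition, with Rattus norvegicus as the target, read by paw edema, with a stated time of 5 h, at a dose of 0.28 mmol/kg by the oral route; a higher number here means more inhibition at the dose given (going by the name of the read-out), a lower number less inhibition. In this assay compound 1 gives 61%, compound 2 gives 51% and compound 3 gives 71%.

Compound 1 and compound 2 differ in one place: hydrogen in place of methoxy on an aromatic carbon. That change made a number 10 percentage points lower from compound 1 to compound 2 (within the scatter).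

Compound 3 has a different core from compound 1, and the difference between the two cores is not broken down here. Its value is within the scatter of the value of compound 1, and beyond the scatter of the value of compound 2.

Compound 4, `CCn1c(SC/C(=N/O)c2ccccc2)nnc1-c1ccc(OC)cc1`, has not yet been measured. It differs from compound 3 in one place: hydrogen in place of methoxy on an aromatic carbon. Within the data shown here, this is the same kind of change as the one from compound 1 to compound 2, though the place is not the same: here the position is ortho to a methoxy group and meta to a large group, whereas in compound 2 it was para to a large group. Because the earlier change gave a number 10 percentage points lower from compound 1 to compound 2 (within the scatter), the step from compound 3 to compound 4 is expected to be of similar size, a number 10 percentage points lower from compound 3 to compound 4 (within the scatter). On that basis compound 4 is estimated to give 61% in this assay, within a range from 46% to 74%.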

Compound 4, a percentage reported as inhibition, in the whole organism at one dose (the size of the read-out at that dose, not a potency): 71%
The estimate for compound 4 lay 10 percentage points below the measured number; the measured number falls inside the stated range.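

In this assay, hydrogen in place of methoxy on an aromatic carbon gives no change at the digits printed from compound 3 to compound 4 (within the scatter). Set beside the earlier example of this change, the two steps cannot be told apart: the same change on two cores in this assay, a number 10 percentage points lower (within the scatter) from compound 1 to compound 2 and no change at the digits printed (within the scatter) from compound 3 to compound 4, 10 percentage points apart, within the scatter of two such steps

So, in these two pairs, the change behaves alike on both cores as far as this measurement can show, but that is a weak statement: neither step stands clear of the scatter, there are only two pairs, and the place that loses its methoxy differs between them as well as the core, so the two influences cannot be separated and nothing shows that the step would carry over to a further core.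

The compounds shown leave open what other groups would do on this aromatic ring, such as an amine, a carboxylic acid or a longer chain in place of methoxy, since only methoxy and hydrogen appear there. They also leave open how these compounds compare at other doses or times, since each is read at a single dose and a single time, which gives the size of the effect there rather than a potency.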